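The source may report more compounds than this note shows. Statements on the series, on what has been measured and on what is new or still open speak of the compounds shown alone.

Measured so far in an ADME assay on Caco-2 cells (Homo sapiens) for permeability, in the apical to basolateral direction; a higher number here means that the compound crosses the layer faster, a lower number that the compound crosses the layer more slowly:
- compound 1 `COC(=O)N1CCN([C@H]2CC[C@H](Nc3ncnn4ccc([C@H](C)CC(=O)N(C)C)c34)CC2)CC1`: 18 10^-6 cm/s
- compound 2 `CC(C)n1ccc2ncnc(N[C@H]3CC[C@H](N(C)C)CC3)c21`: 4.2 10^-6 cm/s

Compound 1 stands highest of the two, and the gap down to compound 2 lies beyond the usual scatter. Compound 3 `COC(=O)N1CCN([C@H]2CC[C@H](Nc3ncnn4ccc([C@H](C)CC(N)=O)c34)CC2)CC1` keeps the core of compound 1 but carries amino in place of dimethylamino on a carbonyl carbon. Among the compounds with values here, no measured pair of compounds shows this change, so what follows is judgement and not a trend from data. In this assay a fall beyond the scatter is expected, a 3.0-fold lower number from compound 1 to compound 3 (0.48 log units; beyond the scatter). For compound 3 the estimated value is 6 10^-6 cm/s, with an expected range from 2.5 10^-6 cm/s to 13 10^-6 cm/s.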

Compound 3, apparent permeability: 17 10^-6 cm/s
Estimate against measurement, compound 3: 2.8-fold (0.45 log units) below; the measured number lies above the stated range.
By their numbers in this assay, from the lowest: compound 2; then compounds 3 and 1 (each within the scatter of the next).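

Replacing dimethylamino with amino on a carbonyl carbon brings in a hydrogen-bond donor, yet in this assay the result is a 1.1-fold lower number from compound 1 to compound 3 (0.02 log units; within the scatter). Within the data shown here, at this position, then, the change leaves no readable difference in this pair, which is the first direct comparison of the two groups. Nothing available here explains why the two numbers stay so close. Going by these compounds, whether methylamino, or a carboxylic acid in place of the whole carbamoyl group, would behave the same remains open. This single pair also cannot say whether the result holds on other cores.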